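From chloro to methoxy: compound 3 and compound 4

This account rests on a few compounds, and the source may have more. Where it says the series, first, only, none or still open, it means among the compounds named here.

Measured in an ADME assay on Jurkat cells (Homo sapiens) for cytotoxicity, read by MTT assay; a higher number here means a weaker inhibitor, a lower number a stronger inhibitor:
Compound 1 `C/C(COc1cccc2ccccc12)=N\O`: > 50000 nM, a limit
Compound 2 `O/N=C(\COc1cccc2ccccc12)c1ccc(F)cc1`: > 50000 nM, a limit
Compound 3 `O/N=C(\COc1cccc2ccccc12)c1ccc(Cl)cc1`: > 50000 nM, a limit

Compound 3 has no exact number, only the limit > 50000 nM. It shares that position with the other two compounds, as the record shows (the limit of > 50000 nM in this assay, at which 3 of the 3 values shown sit). Compound 4 `COc1ccc(/C(COc2cccc3ccccc23)=N/O)cc1` has methoxy in place of chloro on an aromatic carbon, para to a large group: methoxy in place of chloro on an aromatic carbon.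

For the measured compounds named here, one measured step bears on this change: a step that the two limits leave unreadable from compound 2 to compound 3. It is also a swap of one group on an aromatic carbon, chloro in place of fluoro, but with limits at both ends it gives no size to carry over. Going by the values given here, no measured compound in this assay has yet given a number, so no direction can be argued from the data. The expected change is therefore none beyond the scatter, an estimated a number no higher from compound 3 to compound 4 (the limit leaves the size open). Compound 4 will most likely be reported at the same limit. For compound 4 the estimated value is 50000 nM, with an expected range of 25000 nM to 100000 nM.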

Compound 4, half-maximal inhibitory concentration: 31800 nM
Beside the measured number, compound 4's estimate is 1.6-fold (0.20 log units) above it; the range from low to high includes it.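

In this assay compound 4 is the only one of the compounds shown that gives a number and not a limit, so with methoxy on an aromatic carbon, para to a large group, the reading comes inside the measured range, which chloro and fluoro at that place did not do: the limit of > 50000 nM in this assay, at which 3 of the 4 values shown sit.
Methoxy in place of chloro gives an at least 1.5-fold lower number from compound 3 to compound 4 (0.19 log units; that floor lies within the scatter), and methoxy in place of fluoro gives an at least 1.5-fold lower number from compound 2 to compound 4 (0.19 log units; that floor lies within the scatter). As far as these compounds go, both are floors only, so the true size of each step stays unknown, and the step between the other two aromatic compounds still cannot be read.

From the compounds shown here alone, whether a methyl, a hydroxy or an amine on that carbon would also give a number remains open. For the compounds shown here, there is only a single exact value so far. No trend across groups at this position can be read from it.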